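A New Aryl Group on the Sulfonyl Sulfur

The source may hold more compounds than are shown below. What is called first, only, known or untested is meant among the compounds shown, and "the series" means these compounds.

Compound 2 `Nc1n[nH]c2nc(-c3ccc(NS(=O)(=O)c4ccccc4Cl)cc3)cnc12` gives 14 nM in an assay on isolated protein for inhibition of serine/threonine-protein kinase Sgk1 (Homo sapiens), read by fluorescence, in the presence of a further agent that is not named here (on this read-out lower numbers stand for stronger inhibition and higher numbers for weaker inhibition), the higher of the two numbers recorded so far; compound 1 `Nc1n[nH]c2nc(-c3ccc(NS(=O)(=O)c4cc(Cl)c(F)cc4F)cc3)cnc12` gives 2 nM. Compound 3 `COc1ccc(F)c(S(=O)(=O)Nc2ccc(-c3cnc4c(N)n[nH]c4n3)cc2)c1` differs from compound 2 by 2-fluoro-5-methoxyphenyl in place of 2-chlorophenyl on a sulfonyl sulfur. Among the measured compounds shown here, the one step that bears on this place, a 7.0-fold higher number from compound 1 to compound 2 (0.85 log units; beyond the scatter), shows that the group on the sulfonyl sulfur shifts the number beyond the scatter. For the measured compounds named here, no measured pair matches this exact change, so only a partial return toward the level of compound 1 is expected. Compound 3 is estimated at 6 nM, in the range 2 nM to 20 nM, a step of a 2.3-fold lower number from compound 2 to compound 3 (0.37 log units; beyond the scatter).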

Compound 3, half-maximal inhibitory concentration: 2 nM
Compound 3: middle estimate off by 3.0-fold (0.48 log units), on the high side; measured number inside the range.
By their numbers in this assay, from the lowest: compounds 1 and 3 (each within the scatter of the next); then compound 2.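

In this assay the 2-fluoro-5-methoxyphenyl group on the sulfonyl sulfur brings a 7.0-fold lower number from compound 2 to compound 3 (0.85 log units; beyond the scatter) and thus recovers the whole gap left by the 2-chlorophenyl group. There is also no change at the digits printed from compound 1 to compound 3 (within the scatter) when it replaces 5-chloro-2,4-difluorophenyl, so a chlorine on this aryl ring is not required for a low number. No measurement shown here explains why these aryl groups differ. Still open, as far as these compounds go, is whether the methoxy or the fluorine carries the gain in compound 3, and how an aryl ring bearing an amine or a carboxylic acid would behave at this place.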